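This account rests on a few compounds, and the source may have more. Where it says the series, first, only, none or still open, it means among the compounds named here.

Compound 1, with the structure `CCCc1c(OCCCOc2cc(O)c(-c3ccc(F)cc3)cc2CC)ccc2c1OC(C(=O)O)CC2`, carries a propyl chain and a three-carbon linker joining its acid-bearing core to a second aromatic part that ends in a 4-fluorophenyl group. In a functional assay for inhibition of leukotriene B4 receptor (Homo sapiens) (a lower number here means a stronger inhibitor, a higher number a weaker inhibitor), compound 1 gives 17 nM. Going by the values given here, the only other compound with a number here is compound 2, `CCc1cc(-c2ccc(F)cc2)c(O)cc1OCCCOc1ccccc1CCC(=O)O`, which keeps the 4-fluorophenyl part but has a simpler acid-bearing end; in this assay compound 2 gives 31 nM. Of these two numbers, that of compound 1 is the smaller, yet the gap between them lies within the usual scatter of repeated measurements, so the two compounds cannot be told apart on this evidence.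

Compound 3, `CCCc1c(OCCCOc2cc(O)c(-c3ccccc3)cc2CC)ccc2c1OC(C(=O)O)CC2`, is compound 1 with one change: hydrogen in place of fluoro on an aromatic carbon. Among the compounds with values here, no measured pair showing this same change is available, so any expectation rests on the size of the group removed and on the numbers for compound 1 alone. A small shift is expected, toward a weaker inhibitor if any, giving a step of a 1.5-fold higher number from compound 1 to compound 3 (0.17 log units; within the scatter) that may well stay inside the scatter. Compound 3 is therefore estimated at 25 nM, with a range from 10 nM to 60 nM.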

Compound 3, half-maximal inhibitory concentration: 110 nM
Beside the measured number, compound 3's estimate is 4.4-fold (0.64 log units) below it; the whole stated range lies below it.
By their numbers in this assay, from the lowest: compounds 1 and 2 (each within the scatter of the next); then compound 3.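

In this assay, replacing the fluoro of the 4-fluorophenyl group with hydrogen gives a 6.5-fold higher number from compound 1 to compound 3 (0.81 log units; beyond the scatter), a step toward a weaker inhibitor, so the loss of one heavy atom at this place is enough to move the number beyond the usual scatter. Compound 1 and compound 2 could not show this: both carry the fluoro and they differ from each other in more than one place, so the position had no measured comparison of its own until this pair. No measurement shown here bears on why the step has this size.

On these data alone, whether this result is specific to fluoro stays open, since chloro, methyl or methoxy at the same place would show whether a group other than fluoro goes with the lower number as well. Also open, as far as these compounds go, is whether the same change from 4-fluorophenyl to phenyl would weigh as much in compound 2, with its simpler acid-bearing end, as it does on the core of compound 1.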